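Swapping a chlorophenyl for benzofuranyl on a nucleoside core

The source may hold more compounds than are shown below. What is called first, only, known or untested is meant among the compounds shown, and "the series" means these compounds.

Of the compounds shown here, three built on the same core have been tested for how strongly they inhibit in a functional assay on CCRF-CEM cells (Homo sapiens) for inhibition; on this read-out higher numbers stand for weaker inhibition and lower numbers for stronger inhibition. Compound 1 `OC[C@H]1OC(n2cnc3c(-c4ccc(Cl)cc4)ncnc32)[C@H](O)[C@@H]1O` gives 900 nM, the highest of the two numbers recorded. Compound 2 `OC[C@H]1OC(n2cnc3c(-c4ccco4)ncnc32)[C@H](O)[C@@H]1O` gives 600 nM, and the step of a 1.5-fold lower number from compound 1 to compound 2 (0.18 log units; within the scatter) lies within the scatter, so these two cannot be told apart. Compound 3 `Cn1nccc1-c1ncnc2c1ncn2C1O[C@H](CO)[C@@H](O)[C@H]1O` was reported as "not active" (no number reported), without a number.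

The new compound 4 `OC[C@H]1OC(n2cnc3c(-c4cc5ccccc5o4)ncnc32)[C@H](O)[C@@H]1O` differs from compound 1 in one place: 1-benzofuran-2-yl in place of 4-chlorophenyl on an aromatic carbon. Going by the values given here, the only measured step that bears on this is the one from compound 1 to compound 2, where a furan-2-yl took the place of the same 4-chlorophenyl and left the number essentially unchanged. The 1-benzofuran-2-yl of compound 4 carries the same five-membered ring with one oxygen plus a fused six-membered ring, so no shift beyond the scatter is expected, and the step of a 1.3-fold lower number from compound 1 to compound 4 (0.11 log units; within the scatter) is estimated to be small. For compound 4 the expected value is 700 nM, with a range from 250 nM to 2500 nM.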

Compound 4, half-maximal inhibitory concentration: 15000 nM
Estimate against measurement, compound 4: 21-fold (1.33 log units) below, and the stated range ends below it.
By their numbers in this assay, from the lowest: compounds 2 and 1 (each within the scatter of the next); then compound 4.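

In this assay, this aromatic carbon next to the ring nitrogen does not treat all aromatic groups alike: 4-chlorophenyl and furan-2-yl could not be told apart, but 1-benzofuran-2-yl gives a 17-fold higher number from compound 1 to compound 4 (1.22 log units; beyond the scatter). The comparison with the closest group is the more telling one, since 1-benzofuran-2-yl contains the five-membered aromatic ring of furan-2-yl along with a six-membered aromatic ring of carbon only, and that change gives a 25-fold higher number from compound 2 to compound 4 (1.40 log units; beyond the scatter). Nothing available explains this large loss of inhibition.

From the compounds shown here alone, it remains open whether any addition to furan-2-yl has this effect, or only a complete fused ring, and a single methyl group on the furan would begin to test that. Going by these compounds, how an amine or a carboxylic acid at this place would behave also remains unknown.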